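This account rests on a few compounds, and the source may have more. Where it says the series, first, only, none or still open, it means among the compounds named here.

Compound 1, `CCCCCCOP(=O)(O)OCCSC(=S)N1CCCC1`, in an ADME assay on HEK293 cells (Homo sapiens) for inhibition, read by MTT assay, with stated times of 18 h and 4 h (a higher number here means a weaker inhibitor, a lower number a stronger inhibitor), reaches only the limit > 100000 nM.
Compound 2, `CCCCCCCCOP(=O)(O)OCCSC(=S)N1CCCC1`, in this assay gives 28300 nM.
Compound 3, `CCCCCCCCCCCCCCCCOP(=O)(O)OCCSC(=S)N1CCN(C)CC1`, in this assay reaches only the limit > 100000 nM.

Compound 3 thus sits at the limit of > 100000 nM in this assay, at which 2 of the 3 values shown sit, and has no number of its own. Compound 4, `CCCCCCCCCCCCCCCCOP(=O)(O)OCCSC(=S)N1CCCC1`, differs from it by pyrrolidin-1-yl in place of 4-methylpiperazin-1-yl on a thiocarbonyl carbon. Among the measured compounds shown here, no measured step covers this ring exchange; the only measured step, an at least 3.5-fold lower number from compound 1 to compound 2 (0.54 log units; beyond the scatter), concerns the chain rather than the thiocarbonyl substituent, so it gives no direction for the change from compound 3 to compound 4. The step from compound 3 to compound 4 is expected to be an at least 2.0-fold lower number from compound 3 to compound 4 (0.30 log units; that floor lies within the scatter). That expectation rests on compound 2, which carries the pyrrolidin-1-yl group and gives 28300 nM. Compound 4 is estimated at 50000 nM, between 15000 nM and 200000 nM, with a real chance that only a limit is again reported.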

Compound 4, half-maximal inhibitory concentration: > 100000 nM
Compound 4 was reported as a limit; the forecaster's own chance of this, stated with the estimate: 45%; middle value at least 2.0-fold (0.30 log units) away from the limit.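

The chain does not act in one direction on this core in this assay: after an at least 3.5-fold lower number from compound 1 to compound 2 (0.54 log units; beyond the scatter), octyl in place of hydrogen on the chain gives an at least 3.5-fold higher number from compound 2 to compound 4 (0.54 log units; beyond the scatter). Compound 4 is itself only a limit: the limit of > 100000 nM in this assay, at which 3 of the 4 values shown sit. The steps from compound 3 and from compound 1 to compound 4 cannot be read, so the exchange on the thiocarbonyl carbon has no size.

Still open, going by these compounds, is whether a decyl chain on the pyrrolidin-1-yl compounds would give a number of its own. On these data alone, it is also open whether 4-methylpiperazin-1-yl would give one on an octyl chain.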